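The source may hold more compounds than are shown below. What is called first, only, known or untested is meant among the compounds shown, and "the series" means these compounds.

Values in a functional assay on A549 cells (Homo sapiens) for antiproliferative activity, read by MTT assay, with a stated time of 48 h; on this read-out higher numbers stand for weaker inhibition and lower numbers for stronger inhibition:
- compound 1 `Fc1ccc2[nH]c(-c3cn(-c4ccccc4)nc3-c3ccccc3)nc2c1`: 1720 nM
- compound 2 `Clc1ccc2[nH]c(-c3cn(-c4ccccc4)nc3-c3ccccc3)nc2c1`: 2370 nM
- compound 3 `FC(F)(F)c1ccc2[nH]c(-c3cn(-c4ccccc4)nc3-c3ccccc3)nc2c1`: 5930 nM

Compound 2 has the second highest of these three numbers. The step of a 1.4-fold higher number from compound 1 to compound 2 (0.14 log units; within the scatter), while the step of a 2.5-fold higher number from compound 2 to compound 3 (0.40 log units; beyond the scatter).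

Compound 4 `COc1ccc(-c2nn(-c3ccccc3)cc2-c2nc3cc(Cl)ccc3[nH]2)cc1` keeps the chloro group of compound 2 and changes phenyl to 4-methoxyphenyl: methoxy in place of hydrogen on an aromatic carbon. Within the data shown here, no measured step touches this place, since all three only exchange fluoro, chloro and trifluoromethyl. They offer only a rough guide to size, the largest being a 3.4-fold higher number from compound 1 to compound 3 (0.54 log units; beyond the scatter), and they give no direction. In this assay, no change beyond the scatter is therefore expected, and the expected step is a 1.1-fold lower number from compound 2 to compound 4 (0.03 log units; within the scatter). Compound 4 is estimated at 2200 nM, within an expected range of 750 nM to 6500 nM.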

Compound 4, half-maximal inhibitory concentration: 3130 nM
For compound 4 the middle estimate is 1.4-fold (0.15 log units) below the measured one; low and high end bracket the measured number.
By their numbers in this assay, from the lowest: compounds 1, 2, 4 and 3 (each within the scatter of the next, the first and the last beyond it).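

Among these compounds, the earlier compounds exchanged only fluoro, chloro and trifluoromethyl, so this is the first step to touch the phenyl group. In this assay, changing phenyl to 4-methoxyphenyl gives a 1.3-fold higher number from compound 2 to compound 4 (0.12 log units; within the scatter), so with chloro kept, this place takes a methoxy group with no change beyond the scatter. Nothing measured here bears on why the number stays so close.

As far as these compounds go, whether an amine, a carboxylic acid or a longer chain such as ethoxy would be tolerated at this place stays open. So does whether methoxy would give the same result alongside fluoro or trifluoromethyl instead of chloro.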